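Chloro for Methyl on a Sulfamoylamino Benzamide Core

The source may hold more compounds than are shown below. What is called first, only, known or untested is meant among the compounds shown, and "the series" means these compounds.

Measured compounds:
compound 1, `CCN1CCCC1CNC(=O)c1cc(NS(=O)(=O)N(C)C)c(C)cc1OC`, 0.05 mg/kg
compound 2, `CCN1CCCC1CNC(=O)c1cc(NS(=O)(=O)N(C)C)c(Cl)cc1OC`, 0.05 mg/kg
compound 3, `CCN1CCCC1CNC(=O)c1cc(NS(N)(=O)=O)c(C)cc1OC`, > 1 mg/kg

In a functional assay on the whole organism for inhibition, with Canis familiaris (Canis lupus familiaris) as the target (a lower number here means that less compound is needed, a higher number that more compound is needed for the effect), compound 1 gives 0.05 mg/kg. Compound 2 gives 0.05 mg/kg, so that the step of no change at the digits printed from compound 1 to compound 2 (within the scatter), brought about by chloro in place of methyl on an aromatic carbon, stays within the scatter. For compound 3 the assay gives only a limit, > 1 mg/kg. The step of an at least 20-fold higher number from compound 1 to compound 3 (1.30 log units; beyond the scatter) follows (amino in place of dimethylamino on a sulfonyl sulfur), and its size rests on (the limit of > 1 mg/kg in this assay, at which 1 of the 3 values shown sits).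

Compound 4, `CCN1CCCC1CNC(=O)c1cc(NS(N)(=O)=O)c(Cl)cc1OC`, has not yet been measured. It differs from compound 3 by chloro in place of methyl on an aromatic carbon, the same kind of change as from compound 1 to compound 2, though here the place is ortho to a sulfamoylamino group rather than to a (dimethylsulfamoyl)amino group. Because no change at the digits printed from compound 1 to compound 2 (within the scatter) lay within the scatter, the step that the limit leaves unreadable from compound 3 to compound 4 is expected to be small. Compound 4 is therefore estimated at 2 mg/kg, with a range from 0.7 mg/kg to 8 mg/kg, and the assay may again report only a limit.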

Compound 4, dose for half-maximal effect: 1 mg/kg
The estimate for compound 4 lay 2.0-fold (0.30 log units) above the measured number; measured number inside the range.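

Whether chloro in place of methyl carries over from one core to the other in this assay cannot be judged, as this change gives a number no higher from compound 3 to compound 4 (the limit leaves the size open) and that step cannot be read: the same change on two cores in this assay, no change at the digits printed (within the scatter) from compound 1 to compound 2 and a number no higher (the limit leaves the size open) from compound 3 to compound 4; the limit leaves it open whether they differ. Compound 3 stands only as a limit of > 1 mg/kg. Amino in place of dimethylamino on the sulfonyl sulfur gives a 20-fold higher number from compound 2 to compound 4 (1.30 log units; beyond the scatter) and points the same way on both cores, which shows that the direction carries over but not that the size does: the same change on two cores in this assay, an at least 20-fold higher number (1.30 log units; beyond the scatter) from compound 1 to compound 3 and a 20-fold higher number (1.30 log units; beyond the scatter) from compound 2 to compound 4; the limit leaves it open whether they differ.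

The compounds shown leave open what bromo on that aromatic carbon would give. They also leave open where a methylamino group on the sulfonyl sulfur would fall.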